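The source may hold more compounds than are shown below. What is called first, only, known or untested is meant among the compounds shown, and "the series" means these compounds.

In a physicochemical assay for metabolic stability, read by HPLC, in phosphate buffer, at pH 7.4 (a higher number here means that the compound lasts longer, a lower number that the compound disappears faster), compound 1 `CN(/N=N/c1ccc(C#N)cc1)C(=O)CCc1ccc(O)cc1` gives 76 h, compound 2 `CN(/N=N/c1ccc(C(N)=O)cc1)C(=O)CCc1ccc(O)cc1` gives 118 h and compound 3 `COC(=O)c1ccc(/N=N/N(C)C(=O)CCc2ccc(O)cc2)cc1` gives 102 h, so compound 1 stands within the scatter of both others. Compound 4 `CN(/N=N/c1ccc(C#N)cc1)C(=O)CCc1cccc(O)c1` differs from compound 1 by 3-hydroxyphenyl in place of 4-hydroxyphenyl on a saturated chain carbon, two bonds along the chain from a carbonyl carbon, with 3-hydroxyphenyl in place of 4-hydroxyphenyl on a saturated chain carbon. Going by the values given here, no measured step makes this change. The available steps replace the cyano group, giving a 1.6-fold higher number from compound 1 to compound 2 (0.19 log units; within the scatter) and a 1.3-fold higher number from compound 1 to compound 3 (0.13 log units; within the scatter), and both stay within the scatter. With nothing else to go on, no step beyond the scatter is expected in this assay, and the expected outcome is a 1.1-fold higher number from compound 1 to compound 4 (0.02 log units; within the scatter). The half-life of compound 4 is estimated at 80 h, within a range from 45 h to 140 h.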

Compound 4, half-life: 60.1 h
The estimate for compound 4 lay 1.3-fold (0.12 log units) above the measured number; measured number inside the range.
By their numbers in this assay, from the lowest: compounds 4, 1, 3 and 2 (each within the scatter of the next).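

The earlier steps shown here replaced only the cyano group, whereas this one changes the other side of the molecule, on a saturated chain carbon, two bonds along the chain from a carbonyl carbon. In this assay, 3-hydroxyphenyl in place of 4-hydroxyphenyl gives a 1.3-fold lower number from compound 1 to compound 4 (0.10 log units; within the scatter), so this exchange also stays within the scatter. No available evidence bears on this result. Still open, from the compounds shown here alone, is whether a carboxylic acid, an amine or a longer chain at this place would leave the scatter. Also open, going by these compounds, is whether 3-hydroxyphenyl behaves alike with carbamoyl or methoxycarbonyl in place of cyano.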